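Amide series: acid versus fluorophenyl on the ethenyl arm

The compounds below may be only part of what the source reports. "The series", "measured", "known", "first", "only" and "open" are said of these compounds alone.

Measured so far:
- compound 1, `COC(=O)/C=C/c1cccc(N(Cc2ccc(/C=C/c3ccc(F)cc3)cc2)C(=O)C(C)C)c1`: 120 nM
- compound 2, `COC(=O)/C=C/c1cccc(N(Cc2ccc(/C=C/C(=O)O)cc2)C(=O)C2CCCCC2)c1`: > 1000 nM

Compound 1, `COC(=O)/C=C/c1cccc(N(Cc2ccc(/C=C/c3ccc(F)cc3)cc2)C(=O)C(C)C)c1`, carries a 2-(4-fluorophenyl)ethenyl arm on the benzyl group and an isobutyryl amide; in an assay on isolated protein with Bile acid receptor (Homo sapiens) as the target (on this read-out lower numbers stand for an effect already at smaller amounts and higher numbers for an effect only at larger amounts of compound), compound 1 gives 120 nM. Compound 2, `COC(=O)/C=C/c1cccc(N(Cc2ccc(/C=C/C(=O)O)cc2)C(=O)C2CCCCC2)c1`, carries a cyclohexanecarbonyl amide and a 2-carboxyethenyl arm. For compound 2 this assay returns only a limit, > 1000 nM, so compound 2 stands at the weak end of the two values shown, as described in the limit of > 1000 nM in this assay, at which 1 of the 2 values shown sits. Going by the values given here, no step between the two measured compounds can be counted, since they differ in two places at once.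

Compound 3, `COC(=O)/C=C/c1cccc(N(Cc2ccc(/C=C/c3ccc(F)cc3)cc2)C(=O)C2CCCCC2)c1`, keeps the cyclohexanecarbonyl amide of compound 2 and changes only the arm: 4-fluorophenyl in place of carboxy on a double-bonded chain carbon bound to a double-bonded chain carbon. With this change compound 3 carries the same 2-(4-fluorophenyl)ethenyl arm that compound 1 shows with 120 nM. Among the compounds with values here, the step from compound 2 to compound 3 is expected to be a gain in this assay well beyond the scatter, an at least 6.6-fold lower number from compound 2 to compound 3 (0.82 log units; beyond the scatter), because compound 1 gives 120 nM as the only measured compound bearing this arm. Compound 3 is therefore estimated at 150 nM, within 40 nM to 600 nM.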

Compound 3, half-maximal effective concentration: 185 nM
Estimate against measurement, compound 3: 1.2-fold (0.09 log units) below; low and high end bracket the measured number.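

In this assay, going by these compounds alone, with the cyclohexanecarbonyl amide held fixed, 4-fluorophenyl in place of carboxy on a double-bonded chain carbon bound to a double-bonded chain carbon gives an at least 5.4-fold lower number from compound 2 to compound 3 (0.73 log units; beyond the scatter), the first reading of this arm change in which only one place differs. The size of that step has only one bound, set by a limit and not by a number: the limit of > 1000 nM in this assay, at which 1 of the 3 values shown sits. Cyclohexyl in place of isopropyl on a carbonyl carbon, with the 2-(4-fluorophenyl)ethenyl arm kept, gives a 1.5-fold higher number from compound 1 to compound 3 (0.19 log units; within the scatter), so with this arm the two amides are not told apart in this assay.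

The compounds shown leave open how much of the step from carboxy to 4-fluorophenyl belongs to the aromatic ring and how much to its fluorine, a question that an unsubstituted phenyl on the same ethenyl arm would address. They also leave open whether the arm tolerates anything other than an aromatic ring at this place, such as a primary amide or a longer alkyl chain, and whether the two amides stay level with a carboxy arm.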